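A few compounds are considered here, and "the series" means these few. Any claim that something is new, unique, unknown or untested is made for them only; others in the source may bear on it.

Measured in a functional assay on T98G cells (Homo sapiens) for inhibition, read by MTT assay, with a stated time of 72 h; on this read-out lower numbers stand for stronger inhibition and higher numbers for weaker inhibition:
- Compound 1 `CC(C)NC(=S)NC1CC(C)(C)Oc2ccc(Cl)cc21`: 91000 nM
- Compound 2 `CC(C)NC(=O)NC1CC(C)(C)Oc2ccc(Cl)cc21`: > 100000 nM (a limit)

For the measured compounds named here, compound 1 holds the only true number in this assay, as the value for compound 2 is a limit of the assay. Compound 3 `CC1(C)CC(NC(=S)Nc2ccccc2)c2cc(Cl)ccc2O1` keeps the core of compound 1 but carries phenyl in place of isopropyl on an amide-type nitrogen. Going by the values given here, the one measured step, an at least 1.0-fold higher number from compound 1 to compound 2 (0.04 log units; that floor lies within the scatter), leaves isopropyl untouched and its floor lies within the scatter, so it offers little guidance. The estimate therefore stays anchored on compound 1 at 91000 nM, and only a modest move to a lower number is expected: a 2.0-fold lower number from compound 1 to compound 3 (0.31 log units; beyond the scatter). For compound 3, the estimated value is 45000 nM, with an expected range of 13000 nM to 100000 nM.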

Compound 3, half-maximal inhibitory concentration: 37000 nM
Estimate against measurement, compound 3: 1.2-fold (0.09 log units) above; the measured number falls inside the stated range.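

In this assay, phenyl in place of isopropyl on the amide-type nitrogen gives a 2.5-fold lower number from compound 1 to compound 3 (0.39 log units; beyond the scatter). For the compounds shown here, this is the first readable step at this position: the group on this nitrogen can be swapped for a six-membered aromatic ring without losing the effect, and the modest change lies beyond the scatter. Nothing shown explains why the step has this size.

As far as these compounds go, whether a benzyl group, a cyclohexyl ring or a longer chain on this nitrogen would move the number further remains open. So does whether a substituted phenyl, such as methoxyphenyl, would do so.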